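The source may hold more compounds than are shown below. What is called first, only, known or untested is meant among the compounds shown, and "the series" means these compounds.

In a functional assay on HCT-116 cells (Homo sapiens) for inhibition, read by CCK-8 assay, with a stated time of 48 h (a lower number here means a stronger inhibitor, a higher number a weaker inhibitor), the two measured compounds stand as follows:

Compound 1 `COc1cc(-c2cc3nccc(-c4c[nH]c5ccccc45)n3n2)cc(OC)c1OC`: > 10000 nM, which is a limit of the assay and not a number.
Compound 2 `COc1ccc(-c2cc3nccc(-c4cc(OC)c(OC)c(OC)c4)n3n2)cc1F`: 2840 nM.

Among the two results in this assay, compound 2 carries the only value that is an actual number; the other result is a limit, as recorded in the limit of > 10000 nM in this assay, at which 1 of the 2 values shown sits. Going by the values given here, no pair of compounds that differ in only one place has been measured, so there is no measured step to lean on, and nothing here says what removing a fluoro group does to potency.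

Compound 3 `COc1ccc(-c2cc3nccc(-c4cc(OC)c(OC)c(OC)c4)n3n2)cc1` has not yet been measured. It differs from compound 2 in one place: hydrogen in place of fluoro on an aromatic carbon. The change is small, fluoro giving way to hydrogen on the ring that carries the methoxy group. Without a measured step of this kind, the expectation is that the step in this assay stays within the usual scatter, perhaps leaning slightly toward a weaker inhibitor. The expected step is a 1.2-fold higher number from compound 2 to compound 3 (0.09 log units; within the scatter). Compound 3 is estimated at 3500 nM, within a range from 1400 nM to 9000 nM.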

Compound 3, half-maximal inhibitory concentration: 404 nM
The estimate for compound 3 lay 8.7-fold (0.94 log units) above the measured number; measured number outside the range, below it.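

In this assay, putting hydrogen in place of fluoro gives a 7.0-fold lower number from compound 2 to compound 3 (0.85 log units; beyond the scatter), so the 4-methoxyphenyl group makes compound 3 the stronger inhibitor of this pair. Going by these compounds alone, this is the first measured step, and it shows that a single atom on an aromatic carbon, ortho to a methoxy group, can move potency well beyond the usual scatter of the assay. The direction is also informative: at this place and on this core the fluoro goes with a weaker inhibitor. Nothing shown here explains why the step is this large.

This single pair cannot show whether the fluoro is a particular drawback or whether any group at this place would weaken inhibition, and a comparison with chloro, hydroxyl or an amine there would begin to separate those possibilities. It also leaves open whether the same change would have a similar effect with a different group in place of the trimethoxyphenyl ring on the other side of the shared core.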